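Naphthalenyl thioether variant of an aminophenyl cinnamamide

This account rests on a few compounds, and the source may have more. Where it says the series, first, only, none or still open, it means among the compounds named here.

Measured compounds:
Compound 1 `Cc1cc(C)cc(SCc2ccc(/C=C/C(=O)Nc3ccccc3N)cc2)c1`, 47.3%
Compound 2 `Nc1ccccc1NC(=O)/C=C/c1ccc(CSc2ccc(F)cc2)cc1`, 59.1%

The study is read in a functional assay on A549 cells (Homo sapiens) for inhibition, read by CCK-8 assay, with a stated time of 72 h, tested at 8 uM; on this read-out higher numbers stand for more inhibition of growth at the one concentration tested and lower numbers for less inhibition of growth. Among the two measured compounds, compound 1 gives the lowest number, 47.3%, and its nearest neighbour is compound 2, which stands higher by a step of a number 11.8 percentage points higher from compound 1 to compound 2 (beyond the scatter).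

Compound 3 `Nc1ccccc1NC(=O)/C=C/c1ccc(CSc2cccc3ccccc23)cc1` is the compound not yet measured. It differs from compound 1 at one place only:

naphthalen-1-yl in place of 3,5-dimethylphenyl on a sulfur

Going by the values given here, only one measured step touches the group on the sulfur: the step of a number 11.8 percentage points higher from compound 1 to compound 2 (beyond the scatter), which changed the aryl ring on the sulfur to a smaller ring and raised the number modestly. Among the compounds with values here, nothing measured bears on a naphthalen-1-yl at this place, and a change to a larger two-ring group cannot be read from the one step. The expectation therefore stays close to compound 1, with wide uncertainty. For compound 3 the estimated step is a number 2.7 percentage points higher from compound 1 to compound 3 (within the scatter), a change expected to lie within the scatter. The estimated value for compound 3 is 50%, in a range from 33% to 67%.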

Compound 3, percent growth inhibition at one concentration: 71.2%
Compound 3: the middle estimate sits 21.2 percentage points below what was measured, outside the stated range (above it).
By their numbers in this assay, from the lowest: compound 1; then compound 2; then compound 3.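

In this assay, the naphthalen-1-yl on the sulfur gives a number 23.9 percentage points higher from compound 1 to compound 3 (beyond the scatter), and it also gives a number 12.1 percentage points higher from compound 2 to compound 3 (beyond the scatter), so the gain is not confined to the comparison with the 3,5-dimethylphenyl group. The earlier pair showed only that exchanging one single-ring aryl group for another could move the number, whereas compound 3 shows that this place also accepts a group with a second six-membered aromatic ring and that, of the three compounds, the highest number belongs to the one carrying it. Nothing given here accounts for the rise, and it remains an observed difference between these compounds at one concentration.

The compounds shown leave open whether the gain depends on the naphthalene being attached through its 1-position, as a naphthalen-2-yl group on the same sulfur would test, or whether a quinolin-8-yl group would retain it. They also leave open whether an aromatic ring is needed at all at this place, a question that a cyclohexyl group or a longer chain such as n-octyl on the sulfur would address.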